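The source may hold more compounds than are shown below. What is called first, only, known or untested is meant among the compounds shown, and "the series" means these compounds.

Compounds measured in an assay on CHO cells for displacement of a labelled ligand from 5-hydroxytryptamine receptor 7 (Homo sapiens); on this read-out higher numbers stand for weaker inhibition and lower numbers for stronger inhibition:
- compound 1 `O=S(=O)(c1ccc(C(F)(F)F)cc1)N(CCCN1CCN(c2ccccc2)CC1)CC1CCCCC1` gives 456 nM
- compound 2 `O=[N+]([O-])c1ccc(S(=O)(=O)N(CCCN2CCN(c3ccccc3)CC2)CC2CCCCC2)cc1` gives 87 nM
- compound 3 `COc1ccc(S(=O)(=O)N(CCCN2CCN(c3ccccc3)CC2)CC2CCCCC2)cc1` gives 567 nM

Compound 3 shares its number with compound 1, the gap being a 1.2-fold higher number from compound 1 to compound 3 (0.09 log units; within the scatter), so the two cannot be told apart; only compound 2 is set apart, by a 6.5-fold higher number from compound 2 to compound 3 (0.81 log units; beyond the scatter) and a 5.2-fold lower number from compound 1 to compound 2 (0.72 log units; beyond the scatter).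

Compound 4 `COc1ccc(S(=O)(=O)N(CCCN2CCN(c3cccc(C(F)(F)F)c3)CC2)CC2CCCCC2)cc1` is reached from compound 3 by trifluoromethyl in place of hydrogen on an aromatic carbon. Every measured step concerns the aromatic carbon that carries trifluoromethyl, nitro or methoxy, and none of them touches the phenyl that becomes 3-(trifluoromethyl)phenyl here. For the measured compounds named here, there is therefore no step that bears directly on this change, and nothing in the data points to a shift in one direction or the other. The expectation is a number for compound 4 close to that of compound 3, with a 1.1-fold lower number from compound 3 to compound 4 (0.05 log units; within the scatter) as the estimated step lying within the scatter. Compound 4 is estimated at 500 nM in this assay, in a range from 180 nM to 1500 nM.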

Compound 4, half-maximal inhibitory concentration: 678 nM
The estimate for compound 4 lay 1.4-fold (0.13 log units) below the measured number; the measured number falls inside the stated range.
By their numbers in this assay, from the lowest: compound 2; then compounds 1, 3 and 4 (each within the scatter of the next).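

In this assay, for the compounds shown here, the step of a 1.2-fold higher number from compound 3 to compound 4 (0.08 log units; within the scatter) is the first to touch the phenyl that becomes 3-(trifluoromethyl)phenyl, a site the earlier compounds left unchanged. With methoxy kept on the other aromatic ring, this position accepts trifluoromethyl, with its four heavy atoms, in place of hydrogen without a shift that can be told from the scatter, so the change leaves compound 4 indistinguishable from compound 3. No supporting measurement shown here offers an explanation for this result.

The compounds shown leave open whether the same change would also stay within the scatter with nitro in place of methoxy, the one group whose compound stands apart. They also leave open how a carboxylic acid or an amine would read on this same aromatic carbon.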